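Lipophilicity notes on pyrrolidine variants of a shared core

The compounds below may be only part of what the source reports. "The series", "measured", "known", "first", "only" and "open" are said of these compounds alone.

Compound 1 `Fc1cccnc1Nc1ncc(-c2cnc3ccc(N4CCNCC4)nn23)cn1`: 0.7
Compound 2 `Fc1cccnc1Nc1ncc(-c2cnc3ccc(N[C@H]4CCNC4)nn23)cn1`: 0.4

In a physicochemical assay for lipophilicity (on this read-out lower numbers stand for lower lipophilicity and higher numbers for higher lipophilicity), compound 2 stands lowest of the two numbers, with compound 1 nearest; the step of a number 0.30 log units lower from compound 1 to compound 2 (within the scatter) lies within the scatter. Compound 3 `Fc1cccnc1Nc1ncc(-c2cnc3ccc(NCCN4CCCC4)nn23)cn1` differs from compound 2 by 2-(pyrrolidin-1-yl)ethyl in place of pyrrolidin-3-yl on a nitrogen on an aromatic ring. Going by the values given here, the only measured step, from compound 1 to compound 2, concerns a different exchange and was within the scatter, so it bears on this change only loosely. A modest rise in this assay is nevertheless expected for compound 3, of about a number 0.40 log units higher from compound 2 to compound 3 (beyond the scatter). The estimate for compound 3 in this assay is 0.8, ranging from 0.3 to 1.4.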

Compound 3, distribution coefficient: 1.5
Compound 3: middle estimate off by 0.70 log units, on the low side; measured number outside the range, above it.
By their numbers in this assay, from the lowest: compounds 2 and 1 (each within the scatter of the next); then compound 3.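

In this assay, 2-(pyrrolidin-1-yl)ethyl in place of pyrrolidin-3-yl on a nitrogen on an aromatic ring gives a number 1.10 log units higher from compound 2 to compound 3 (beyond the scatter), and (2-(pyrrolidin-1-yl)ethyl)amino in place of piperazin-1-yl gives a number 0.80 log units higher from compound 1 to compound 3 (beyond the scatter). This position can therefore shift the number beyond the scatter, which the earlier pair did not show. No evidence on the origin of these steps is at hand.

Still open, from the compounds shown here alone, is whether the step follows the ring or the chain linking it to the nitrogen. A dimethylamino group on the same ethyl chain, or a longer chain ending in pyrrolidin-1-yl, would separate the two.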